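Removal of the ester from the thiazole-side chain

The source may report more compounds than this note shows. Statements on the series, on what has been measured and on what is new or still open speak of the compounds shown alone.

Measured so far in a functional assay on PC-3 cells (Homo sapiens) for antiproliferative activity; a higher number here means a weaker inhibitor, a lower number a stronger inhibitor:
compound 1 `C/C(=N\Nc1nc(-c2ccc(Br)cc2)cs1)c1cc2ccccc2o1` gives 45200 nM
compound 2 `CCOC(=O)Cc1csc(N/N=C(\C)c2cc3ccccc3o2)n1` gives 13100 nM

Within the data shown here, compound 2 has the lowest of the two numbers; the only step measured, a 3.5-fold lower number from compound 1 to compound 2 (0.54 log units; beyond the scatter), brings it there. Compound 3 `C/C(=N\Nc1nc(C)cs1)c1cc2ccccc2o1` differs from compound 2 by hydrogen in place of ethoxycarbonyl on a saturated chain carbon bound to an aromatic carbon. Among the measured compounds shown here, no measured step touches this change; the one step known, a 3.5-fold lower number from compound 1 to compound 2 (0.54 log units; beyond the scatter), concerns a different exchange at the same aromatic carbon and gives no direct guide. A step of modest size, if any, is expected for a 1.5-fold higher number from compound 2 to compound 3 (0.18 log units; within the scatter). Compound 3 is estimated at 20000 nM, in the range 7000 nM to 60000 nM.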

Compound 3, half-maximal inhibitory concentration: 8990 nM
Beside the measured number, compound 3's estimate is 2.2-fold (0.35 log units) above it, within the range that was stated.
By their numbers in this assay, from the lowest: compounds 3 and 2 (each within the scatter of the next); then compound 1.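

In this assay hydrogen in place of ethoxycarbonyl gives a 1.5-fold lower number from compound 2 to compound 3 (0.16 log units; within the scatter) so methyl and (ethoxycarbonyl)methyl are not separated at this position, and the ester is not required for the activity seen. Methyl in place of 4-bromophenyl gives a 5.0-fold lower number from compound 1 to compound 3 (0.70 log units; beyond the scatter) so both small side chains now read apart from 4-bromophenyl. Nothing available explains either result.

Open, on these data alone, is whether a carboxylic acid, an amine or a longer chain at this position would separate from methyl. Also open, as far as these compounds go, is whether unsubstituted phenyl would read like 4-bromophenyl.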